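Adding a Chloro Group to the Core of Compound 2

The compounds below may be only part of what the source reports. "The series", "measured", "known", "first", "only" and "open" are said of these compounds alone.

Compound 2 `c1cc(-c2ccn[nH]2)c2c(c1)C(c1ncc[nH]1)CC2` gives 52 nM in a functional assay on CHO cells for agonist activity at Alpha-1A adrenergic receptor (Homo sapiens), read by FLIPR and calcium flux (a higher number here means that more compound is needed for the effect, a lower number that less compound is needed), the lower of the two numbers measured. Compound 1 `CCCS(=O)(=O)Nc1cccc2c1CCC2c1ncc[nH]1` gives 1340 nM in this assay. Within the data shown here, the one step measured, a 26-fold lower number from compound 1 to compound 2 (1.41 log units; beyond the scatter), swaps one aromatic substituent for another. Compound 3 `Clc1ccc2c(c1-c1ccn[nH]1)CCC2c1ncc[nH]1` differs from compound 2 by chloro in place of hydrogen on an aromatic carbon. That measured step does not involve a chloro group and so does not bear on this change; nothing measured here shows how adding a chloro group shifts the number. For compound 3 the expected step is a 1.2-fold higher number from compound 2 to compound 3 (0.06 log units; within the scatter), a change within the scatter. Compound 3 is therefore estimated at 60 nM, with a range from 20 nM to 200 nM.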

Compound 3, half-maximal effective concentration: 322 nM
Estimate against measurement, compound 3: 5.4-fold (0.73 log units) below; measured number outside the range, above it.
By their numbers in this assay, from the lowest: compound 2; then compound 3; then compound 1.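

Chloro in place of hydrogen on the aromatic carbon ortho to the 1H-pyrazol-5-yl group is not a neutral change: in this assay it gives a 6.2-fold higher number from compound 2 to compound 3 (0.79 log units; beyond the scatter) and so means that more compound is needed for the effect. A single added heavy atom at this position is thus enough to move the number beyond the scatter. Nothing available here explains why the number rises. As far as these compounds go, whether a fluoro, methyl or methoxy group at this position would shift the number as far remains open. So does whether chloro on another aromatic carbon of the core would do the same.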